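Bromo for phenyl on two cores: cytotoxicity notes

The compounds below may be only part of what the source reports. "The series", "measured", "known", "first", "only" and "open" are said of these compounds alone.

Measured so far:
compound 1 `CCCNC(=O)C1CC12CCN(C(=O)c1cc3sc(-c4ccccc4)nc3n1Cc1ccc(OC)cc1)CC2`: > 100000 nM
compound 2 `CCCNC(=O)[C@H]1[C@@H]2CCC[C@H]1CN(C(=O)c1cc3sc(-c4ccccc4)nc3n1Cc1ccc(OC)cc1)C2`: > 100000 nM
compound 3 `CCCNC(=O)C1CC12CCN(C(=O)c1cc3sc(Br)nc3n1Cc1ccc(OC)cc1)CC2`: 81300 nM

In an ADME assay on HEK-293T cells (Homo sapiens) for cytotoxicity, read by luminescence and CellTiter-Glo, with a stated time of 24 h (on this read-out lower numbers stand for higher toxicity in this test and higher numbers for lower toxicity in this test), the value of compound 1 is a limit of the assay, not a number. The value of compound 2 in this assay is likewise a limit. Both sit at the limit of > 100000 nM in this assay, at which 2 of the 3 values shown sit. Compound 3 is the only one of the three with a number in this assay. The change from compound 1 to compound 3 is bromo in place of phenyl on an aromatic carbon; the step of an at least 1.2-fold lower number from compound 1 to compound 3 (0.08 log units; that floor lies within the scatter). The difference between the core of compound 1 and the core of compound 2 is not broken down here.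

Compound 4 `CCCNC(=O)[C@H]1[C@@H]2CCC[C@H]1CN(C(=O)c1cc3sc(Br)nc3n1Cc1ccc(OC)cc1)C2` is not yet measured. It differs from compound 2 by bromo in place of phenyl on an aromatic carbon, the same kind of change as from compound 1 to compound 3, at the same place as worded there. From compound 2 to compound 4 a step of an at least 1.1-fold lower number from compound 2 to compound 4 (0.07 log units; that floor lies within the scatter) is expected, which rests on compound 1 to compound 3 having given an at least 1.2-fold lower number from compound 1 to compound 3 (0.08 log units; that floor lies within the scatter). Compound 4 is therefore estimated at 85000 nM in this assay. For compound 4 the expected range runs from 40000 nM to 200000 nM, with a real chance that only a limit is reported again.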

Compound 4, half-maximal cytotoxic concentration: 57500 nM
The estimate for compound 4 lay 1.5-fold (0.17 log units) above the measured number, within the range that was stated.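

In this assay the bromo compounds on both cores return a number while the phenyl compounds return only a limit of the assay, and on the second core the change reads as an at least 1.7-fold lower number from compound 2 to compound 4 (0.24 log units; that floor lies within the scatter) and no more than that. Compound 2 stands at a limit, not a number, so the true size of this step stays unread, and a fixed size for the change across the two cores cannot be claimed. Set side by side, the two steps come to this: the same change on two cores in this assay, an at least 1.2-fold lower number (0.08 log units; that floor lies within the scatter) from compound 1 to compound 3 and an at least 1.7-fold lower number (0.24 log units; that floor lies within the scatter) from compound 2 to compound 4; the limit leaves it open whether they differ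

Open, on these data alone, is whether the same picture holds on a further core, and whether another group on that aromatic carbon, such as an amine or a nitrile, gives a number in this assay or stays at the limit. Also open, as far as these compounds go, is what a longer chain on the amide would do on either core.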